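Removing a Methyl from the Fused Core

The source may hold more compounds than are shown below. What is called first, only, known or untested is meant among the compounds shown, and "the series" means these compounds.

Three compounds built on a cyclopropyl amide attached to a thiophene, which carries a fused two-ring heteroaromatic, have been measured. In an in vitro ADME assay on microsomes from liver (Homo sapiens) for pharmacokinetics, read by LC-MS (on this read-out lower numbers stand for slow clearance and higher numbers for fast clearance), compound 1 `Cc1nc2cc(C(F)(F)F)ccc2n1-c1ccc(C(=O)NC2CC2)s1` gives 4 mL/min/kg, compound 2 `Cc1nc2c(Cl)cc(F)cc2n1-c1ccc(C(=O)NC2CC2)s1` gives 5 mL/min/kg, and compound 3 `O=C(NC1CC1)c1ccc(-n2cnc3c(Cl)cc(F)cc32)s1` gives 7 mL/min/kg. All three numbers sit within the scatter of one another, so no order among them can be claimed. Compound 1 and compound 2 carry different cores; the difference between the two cores is not broken down here.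

Compound 2 and compound 3 differ in one place only, (hydrogen in place of methyl on an aromatic carbon). This change gave a 1.4-fold higher number from compound 2 to compound 3 (0.15 log units; within the scatter), a step that stays inside the scatter of this assay.

Compound 4 `O=C(NC1CC1)c1ccc(-n2cnc3cc(C(F)(F)F)ccc32)s1` has not yet been measured. It stands to compound 1 exactly as compound 3 stands to compound 2, (hydrogen in place of methyl on an aromatic carbon), the same change made on the other core, and this is the only example of it among the compounds shown. Because the earlier example gave a 1.4-fold higher number from compound 2 to compound 3 (0.15 log units; within the scatter), the number expected for compound 4 in this assay is 5.5 mL/min/kg, a step of a 1.4-fold higher number from compound 1 to compound 4 (0.14 log units; within the scatter). The range from 3 mL/min/kg to 10 mL/min/kg is estimated to hold the value, resting on a single prior step and on the low starting value of compound 1, which sits among the slowest-clearing members of this small set.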

Compound 4, clearance: 8 mL/min/kg
For compound 4 the middle estimate is 1.5-fold (0.16 log units) below the measured one; low and high end bracket the measured number.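

In this assay, hydrogen in place of methyl on the core of compound 1 gave a 2.0-fold higher number from compound 1 to compound 4 (0.30 log units; within the scatter). Set beside the earlier example of the same change, the new step cannot be told apart from it: the same change on two cores in this assay, a 1.4-fold higher number (0.15 log units; within the scatter) from compound 2 to compound 3 and a 2.0-fold higher number (0.30 log units; within the scatter) from compound 1 to compound 4, 1.4-fold (0.15 log units) apart, within the scatter of two such steps. The change therefore carries from one core to the other without any measurable difference between the two steps, but this agreement is weak: each step lies within the scatter, so the two pairs show neither that the methyl matters for clearance on either core nor that the same result would hold on a third core.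

The compounds shown leave open how this position, on an aromatic carbon between two ring nitrogen atoms, would respond to a group other than methyl or hydrogen, such as an ethyl group, a longer chain or an amine. They also leave open how far the clearance reading depends on the cyclopropyl amide shared by all four compounds, since no other amide, and no carboxylic acid in its place, stands among them.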